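The source may report more compounds than this note shows. Statements on the series, on what has been measured and on what is new or still open speak of the compounds shown alone.

Compound 1 `CC(C)(C)OC(=O)C(=O)Nc1cccccc1=O` and compound 2 `CCCCCOC(=O)C(=O)Nc1cccccc1=O` share one core and differ only in the group on an oxygen next to a carbonyl group. In a functional assay on the whole organism (strain Sprague-Dawley CD) for inhibition, with Rattus norvegicus as the target, read by paw edema, at a dose of 30 mg/kg by the oral route (a lower number here means a weaker effect, a higher number a stronger effect of the compound at the dose given), compound 1 gives 47%, while compound 2 gives 12%; the step of a number 35 percentage points lower from compound 1 to compound 2 (beyond the scatter) is beyond the scatter. Among the measured compounds shown here, compound 2 therefore stands at the lower of the two numbers measured so far, with compound 1 as its only and higher neighbour. Compound 3 `CCOC(=O)COC(=O)C(=O)Nc1cccccc1=O` has not been measured; it differs from compound 2 by ethoxycarbonyl in place of butyl on a saturated chain carbon bound to an oxygen next to a carbonyl group. For the measured compounds named here, the single measured step touches the same place and was large, yet it swapped tert-butyl for pentyl, whereas here ethoxycarbonyl replaces butyl, so the direction is open. Compound 3 is expected to give about 25%, between 0% and 55%. That estimate means an expected step of a number 13 percentage points higher from compound 2 to compound 3 (beyond the scatter).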

Compound 3, a percentage reported as inhibition, in the whole organism at one dose (the size of the read-out at that dose, not a potency): 31%
The estimate for compound 3 lay 6 percentage points below the measured number, within the range that was stated.
By their numbers in this assay, from the lowest: compound 2; then compound 3; then compound 1.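

In this assay, ethoxycarbonyl in place of butyl on a saturated chain carbon bound to an oxygen next to a carbonyl group gives a number 19 percentage points higher from compound 2 to compound 3 (beyond the scatter) and so shows that changing the end of the chain, with no branching added at the oxygen, can also move the read-out. The same compound does not close the gap to the tert-butyl group, since (ethoxycarbonyl)methyl in place of tert-butyl gives a number 16 percentage points lower from compound 1 to compound 3 (beyond the scatter) and the three groups therefore sit at three separate levels. Nothing available explains this order.

The compounds shown leave open how a carboxylic acid in place of the ethyl ester, or an amine on the same chain, would behave at this position. A longer chain ending in ethoxycarbonyl also remains an open case, as do branched groups other than tert-butyl.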